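This account rests on a few compounds, and the source may have more. Where it says the series, first, only, none or still open, it means among the compounds named here.

Measured in an ADME assay on CCRF-CEM cells (Homo sapiens), read by XTT assay, with a stated time of 72 h; on this read-out higher numbers stand for weaker inhibition and lower numbers for stronger inhibition:
- compound 1 `O=C1C=CC(=O)C1=C/C=C/c1ccccc1`: 4400 nM
- compound 2 `O=C1C=CC(=O)C1=Cc1ccccc1`: 2600 nM

Compound 2, at 2600 nM, lies within the usual scatter of repeated measurements of compound 1, at 4400 nM, so these two cannot be told apart. Compound 3 `COc1ccc(C=C2C(=O)C=CC2=O)cc1` is compound 2 with one change: methoxy in place of hydrogen on an aromatic carbon. Among the compounds with values here, no measured pair shows this change, so no step beyond the scatter is expected in this assay. The expected size is a 1.2-fold higher number from compound 2 to compound 3 (0.06 log units; within the scatter). For compound 3 the estimated value is 3000 nM, with an expected range of 1200 nM to 7500 nM.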

Compound 3, half-maximal inhibitory concentration: 3800 nM
Beside the measured number, compound 3's estimate is 1.3-fold (0.10 log units) below it, within the range that was stated.
By their numbers in this assay, from the lowest: compounds 2, 3 and 1 (each within the scatter of the next).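

In this assay, within the data shown here, this is the first pair that isolates one change on the aromatic ring, and methoxy in place of hydrogen gives a 1.5-fold higher number from compound 2 to compound 3 (0.16 log units; within the scatter) without leaving the scatter. At this carbon, para to a group of 8 heavy atoms, methoxy therefore produces no readable change in inhibition. Nothing available explains this result.

From the compounds shown here alone, whether an amine, a carboxylic acid or a longer chain such as butoxy at this carbon would shift the number beyond the scatter remains open. So does the effect of methoxy elsewhere on the ring.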